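The source may hold more compounds than are shown below. What is called first, only, known or untested is meant among the compounds shown, and "the series" means these compounds.

Measured so far:
compound 1, `Cc1nc(OCc2c(-c3c(Cl)cccc3Cl)noc2C(C)C)ccc1N(C)C(=O)c1ccc(C(=O)O)cc1`, 21%
compound 2, `CC(C)c1onc(-c2c(Cl)cccc2Cl)c1COc1ccc(N(C)Cc2ccc(CCC(=O)O)cc2)c(C(F)(F)F)n1`, 55%

In a functional assay on HEK293 cells for agonist activity at Bile acid receptor (Homo sapiens) (a higher number here means a larger maximal response, a lower number a smaller maximal response), compound 2 gives the higher of the two numbers; compound 1 sits lower by a margin beyond the usual scatter. The compound that follows is compound 3, `CC(C)c1onc(-c2c(Cl)cccc2Cl)c1COc1ccc(N(C)Cc2ccc(OCCO)cc2)c(C(F)(F)F)n1`, which has not been measured. It differs from compound 2 in one place: 2-hydroxyethoxy in place of 2-carboxyethyl on an aromatic carbon. For the measured compounds named here, no step between measured compounds shows what such a change does here. A moderate fall in this assay is expected for compound 3, with the expected step of a number 20 percentage points lower from compound 2 to compound 3 (beyond the scatter) likely beyond the scatter. Compound 3 is estimated at 35%, within a range from 10% to 65%.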

Compound 3, largest response reached (reported as efficacy), in percent of the reference or control that the assay uses: 43%
The estimate for compound 3 lay 8 percentage points below the measured number, within the range that was stated.
By their numbers in this assay, from the lowest: compound 1; then compound 3; then compound 2.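

In this assay, putting 2-hydroxyethoxy in place of 2-carboxyethyl on this aromatic carbon, para to a large group, gives a number 12 percentage points lower from compound 2 to compound 3 (beyond the scatter) as a modest step. The carboxylic acid of compound 2 is therefore not required at this position for a clear maximal response, though the response does not stay fully intact without it. As far as these compounds go, whether an amine or a longer 3-hydroxypropoxy chain at this carbon would restore or further lower the response remains open. Why the response falls also stays open, as no measurement offered here bears on it.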